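One Methyl Fewer: Expected Metabolic Stability of Compound 3

The source may report more compounds than this note shows. Statements on the series, on what has been measured and on what is new or still open speak of the compounds shown alone.

Compound 1 `Cc1cc(C)c(O)c(-n2c(N)nc3ccccc32)c1`: 10 uL/min
Compound 2 `Cc1cc(O)c(-n2c(N)nc3ccccc32)cc1C`: 13 uL/min

Both compounds were measured in an ADME assay on microsomes from liver (Homo sapiens) for metabolic stability, read by LC-MS, using NADPH, with a stated time of 60 min, tested at 1 uM; a higher number here means faster removal of the compound, a lower number slower removal. Of the two numbers, that of compound 2 is the larger, but its gap to compound 1 lies within the scatter, so the two cannot be told apart.

Compound 3 `Cc1ccc(-n2c(N)nc3ccccc32)c(O)c1` is not yet measured. It differs from compound 2 by hydrogen in place of methyl on an aromatic carbon. For the measured compounds named here, no measured pair shows this change, so its size is unknown; in this assay the step is expected to stay within the scatter, in no clear direction. Compound 3 is therefore expected to give about 12 uL/min, between 6 uL/min and 25 uL/min, which is an estimated step of a 1.1-fold lower number from compound 2 to compound 3 (0.03 log units; within the scatter).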

Compound 3, intrinsic clearance in a liver preparation (reported as CLH), per the amount of preparation that the assay uses in the Homo sapiens assay: 11 uL/min
For compound 3 the middle estimate is 1.1-fold (0.04 log units) above the measured one, within the range that was stated.
By their numbers in the Homo sapiens assay, from the lowest: compounds 1, 3 and 2 (each within the scatter of the next).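

Hydrogen in place of methyl on this aromatic carbon, ortho to a methyl group and para to a hydroxy group, now has a measured size: in the Homo sapiens assay it is a 1.2-fold lower number from compound 2 to compound 3 (0.07 log units; within the scatter) and so gives no clear change. In a physicochemical assay for solubility, read by nephelometry, measured as kinetic solubility, with a stated time of 30 min, at pH 7.4 (a lower number here means a less soluble compound, a higher number a more soluble compound), compound 2 gives 12.5 ug/mL and compound 3 gives 25 ug/mL with a gap that also stays within the scatter. Nothing available here offers an explanation for either result.

Still open, on these data alone, is whether an amine or a longer chain on this same carbon would leave both numbers as close.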